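Hydroxypropyl Triazole Analog Awaits Cytotoxicity Read-out

This account rests on a few compounds, and the source may have more. Where it says the series, first, only, none or still open, it means among the compounds named here.

For the measured compounds named here, compound 2 `CCOC(=O)c1cn(C(c2ccccc2)c2cc3cc(Br)ccc3nc2OC)nn1` gives 16.1% in an ADME assay on PC-3 cells (Homo sapiens) for cytotoxicity, read by sulforhodamine B assay, with a stated time of 48 h, tested at 10 uM (on this read-out lower numbers stand for less inhibition and higher numbers for more inhibition at the one concentration tested (going by the name of the read-out)), the higher of the two numbers measured so far, while compound 1 `CCCCCCc1cn(C(c2ccccc2)c2cc3cc(Br)ccc3nc2OC)nn1` gives 2.32%. Going by the values given here, the only measured step, a number 13.8 percentage points higher from compound 1 to compound 2 (beyond the scatter), concerns the same position on the five-membered aromatic ring with 3 nitrogen that is changed here. Compound 3 `COc1nc2ccc(Br)cc2cc1C(c1ccccc1)n1cc(CCCO)nn1` differs from compound 2 by 3-hydroxypropyl in place of ethoxycarbonyl on an aromatic carbon. The measured step bears on this change only loosely, since neither hexyl nor ethoxycarbonyl is exchanged for the entering 3-hydroxypropyl group, and it was itself only modest. Both measured numbers are low, so the step to compound 3 is expected to be small, a number 8.1 percentage points lower from compound 2 to compound 3 (within the scatter), with a slight lean toward lower inhibition and possibly none beyond the scatter. Compound 3 is therefore estimated to give 8% in this assay, within a range of 0% to 22%.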

Compound 3, a percentage reported as inhibition, at one concentration (the size of the read-out at that concentration, not a potency): 14.7%
Beside the measured number, compound 3's estimate is 6.7 percentage points below it; measured number inside the range.
By their numbers in this assay, from the lowest: compound 1; then compounds 3 and 2 (each within the scatter of the next).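

Exchanging ethoxycarbonyl for 3-hydroxypropyl gives a number 1.4 percentage points lower from compound 2 to compound 3 (within the scatter) in this assay and so does not separate the two groups at this position on the five-membered aromatic ring with 3 nitrogen, even though a hydrogen-bond donor enters and the carbonyl leaves. Hexyl now stands apart from both groups, since a number 12.4 percentage points higher from compound 1 to compound 3 (beyond the scatter) joins a number 13.8 percentage points higher from compound 1 to compound 2 (beyond the scatter) as a second step beyond the scatter, so among these three compounds the number divides the one without oxygen in this group from the two with it. No evidence at hand accounts for this division.

The compounds shown leave open how an amine or a carboxylic acid would read at this position. They also leave open whether a longer chain ending in hydroxy would stay level with 3-hydroxypropyl.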